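The source may report more compounds than this note shows. Statements on the series, on what has been measured and on what is new or still open speak of the compounds shown alone.

Working notes on the series. Compound 1 `COc1cc(-c2nnc(SCC(=O)c3ccccc3)n2N)cc(OC)c1OC` in a functional assay on HepG2 cells (Homo sapiens) for antiproliferative activity, read by MTT assay, with a stated time of 48 h (on this read-out higher numbers stand for weaker inhibition and lower numbers for stronger inhibition), gives 7800 nM. Compound 2 `COc1cc(-c2nnc(SCC(=O)Nc3ccccc3C)n2N)cc(OC)c1OC` reaches only the assay limit in this assay, > 100000 nM. Compound 3 `COc1cccc(NC(=O)CSc2nnc(-c3cc(OC)c(OC)c(OC)c3)n2N)c1` likewise gives only a limit in this assay, > 100000 nM. The relevant boundary is the limit of > 100000 nM in this assay, at which 2 of the 3 values shown sit. Both steps away from compound 1 are large: an at least 12-fold higher number from compound 1 to compound 2 (1.10 log units; beyond the scatter) and an at least 12-fold higher number from compound 1 to compound 3 (1.10 log units; beyond the scatter). Between the two limit compounds, a step that the two limits leave unreadable from compound 2 to compound 3.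

Compound 4 `COc1cc(-c2nnc(SCC(=O)Nc3ccccc3F)n2N)cc(OC)c1OC` differs from compound 3 by 2-fluorophenyl in place of 3-methoxyphenyl on an amide-type nitrogen. Both measured compounds carrying the amide-type nitrogen sit at the limit, and the swap between them is unreadable, so the step of a number no higher from compound 3 to compound 4 (the limit leaves the size open) is expected to be none beyond the scatter. Compound 4 is therefore estimated at 100000 nM, within 30000 nM to 300000 nM, most likely again only as a limit.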

Compound 4, half-maximal inhibitory concentration: 18700 nM
For compound 4 the middle estimate is 5.3-fold (0.73 log units) above the measured one; the measured number lies below the stated range.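

With 2-fluorophenyl on the amide-type nitrogen, the value comes off the limit, with an at least 5.3-fold lower number from compound 3 to compound 4 (0.72 log units; beyond the scatter), and fluoro in place of methyl on an aromatic carbon gives an at least 5.3-fold lower number from compound 2 to compound 4 (0.72 log units; beyond the scatter), so that nitrogen alone does not fix the series at the limit. Even so, inhibition remains weaker than without that nitrogen, with a 2.4-fold higher number from compound 1 to compound 4 (0.38 log units; beyond the scatter). Compound 2 and compound 3 remain limits, not numbers: the limit of > 100000 nM in this assay, at which 2 of the 4 values shown sit.

Open, from the compounds shown here alone, is whether a 2-chlorophenyl or a 3-fluorophenyl group on the amide-type nitrogen would also give a readable value. That would help separate the part played by fluoro from the part played by its place on the ring.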